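Removing the iodo from compound 2

The source may report more compounds than this note shows. Statements on the series, on what has been measured and on what is new or still open speak of the compounds shown alone.

Measured in an ADME assay on MT4 cells (Homo sapiens) for cytotoxicity, read by MTT assay, with a stated time of 5 days; on this read-out lower numbers stand for higher toxicity in this test and higher numbers for lower toxicity in this test:
- Compound 1 `Cc1cc(C)c(Oc2cc(Nc3ccc(C#N)cc3)[nH]c(=O)c2I)c(C)c1`: 34000 nM
- Compound 2 `Cc1cc(C#N)cc(C)c1Oc1cc(Nc2ccc(C#N)cc2)[nH]c(=O)c1I`: > 259000 nM, a limit of the assay and not a number
- Compound 3 `Cc1cc(C)cc(Oc2cc(Nc3ccc(C#N)cc3)[nH]c(=O)c2Cl)c1`: 21000 nM

Compound 2 has no exact value, and its result is the limit of > 259000 nM in this assay, at which 1 of the 3 values shown sits. Compound 4 `Cc1cc(C#N)cc(C)c1Oc1cc(Nc2ccc(C#N)cc2)[nH]c(=O)c1` differs from it by one change, hydrogen in place of iodo on an aromatic carbon, para to a (4-cyanophenyl)amino group: hydrogen in place of iodo on an aromatic carbon.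

Among the measured compounds shown here, no measured step tests this swap directly. The only one, an at least 7.6-fold higher number from compound 1 to compound 2 (0.88 log units; beyond the scatter), is cyano in place of methyl, a different change, and compound 4 keeps that cyano. Compound 3 has chloro rather than iodo and also differs in its methyl groups, so it gives only loose guidance.

A high number in this assay is therefore expected for compound 4, with only weak support from the data. The estimated change, toward a lower number, is an at least 1.7-fold lower number from compound 2 to compound 4 (0.23 log units; that floor lies within the scatter). For compound 4 the estimate is 150000 nM, with an expected range of 30000 nM to 350000 nM.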

Compound 4, half-maximal cytotoxic concentration: 25000 nM
Compound 4: the middle estimate sits 6.0-fold (0.78 log units) above what was measured, and the stated range ends above it.
By their numbers in this assay, from the lowest: compounds 3, 4 and 1 (each within the scatter of the next). At a limit, above all of these: compound 2.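

In this assay, hydrogen in place of iodo on this aromatic carbon, para to a (4-cyanophenyl)amino group, gives an at least 10-fold lower number from compound 2 to compound 4 (1.01 log units; beyond the scatter). Among the compounds shown here, the only earlier step concerned the cyano in place of methyl, whereas this one shows that the iodo position also matters: with the cyano kept and the iodo gone, the number no longer reaches the limit of the assay, moving toward higher toxicity in this test. As far as these compounds go, the real size of the step stays unknown, since compound 2 sits at a limit and not at a number: the limit of > 259000 nM in this assay, at which 1 of the 4 values shown sits.

From the compounds shown here alone, it remains open whether a bromo or an amino group at this position would behave more like iodo or like hydrogen. Compound 3 carries chloro there but also differs in its methyl groups, so it cannot settle this.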